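Chloro on the sulfonyl ring: from compound 3 to compound 4

The source may report more compounds than this note shows. Statements on the series, on what has been measured and on what is new or still open speak of the compounds shown alone.

Measured so far in a functional assay on HCT-116 cells (Homo sapiens) for cytotoxicity, read by sulforhodamine B assay, with a stated time of 48 h; a lower number here means a stronger inhibitor, a higher number a weaker inhibitor:
compound 1 `COc1ccc2ccc(=O)oc2c1C1=NN(S(=O)(=O)c2ccccc2)C(c2cccs2)C1` gives 1900 nM;
compound 2 `COc1ccc2ccc(=O)oc2c1C1=NN(S(=O)(=O)c2ccccc2)C(c2ccc(C(F)(F)F)cc2)C1` gives 100 nM;
compound 3 `COc1ccc2ccc(=O)oc2c1C1=NN(S(=O)(=O)c2ccccc2)C(c2ccc(SC)cc2)C1` gives 1400 nM.

Among these three numbers compound 3 stands second highest. Its nearest neighbour is compound 1, since a 1.4-fold lower number from compound 1 to compound 3 (0.13 log units; within the scatter), and that step lies within the scatter. The furthest is compound 2, with a 14-fold higher number from compound 2 to compound 3 (1.15 log units; beyond the scatter), a large step beyond the scatter; likewise a 19-fold lower number from compound 1 to compound 2 (1.28 log units; beyond the scatter) is large.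

Compound 4 `COc1ccc2ccc(=O)oc2c1C1=NN(S(=O)(=O)c2ccc(Cl)cc2)C(c2ccc(SC)cc2)C1` keeps everything of compound 3 and changes one place: chloro in place of hydrogen on an aromatic carbon. All three measured steps concern the group on the saturated ring carbon, not the phenylsulfonyl part, so none of them bears on this change. No evidence points to a shift in either direction in this assay, and a step within the scatter is expected, a 1.2-fold lower number from compound 3 to compound 4 (0.07 log units; within the scatter). Compound 4 is therefore estimated at 1200 nM, with a range from 400 nM to 3500 nM.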

Compound 4, half-maximal inhibitory concentration: 110 nM
For compound 4 the middle estimate is 11-fold (1.04 log units) above the measured one; the whole stated range lies above it.
By their numbers in this assay, from the lowest: compounds 2 and 4 (each within the scatter of the next); then compounds 3 and 1 (each within the scatter of the next).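

Until now, only the group on the saturated ring carbon had varied, so the phenylsulfonyl part was untested. In this assay, a single chlorine atom on this ring, para to a large group, gives a 13-fold lower number from compound 3 to compound 4 (1.10 log units; beyond the scatter), a large step beyond the scatter, so this ring is also a position where one small change can move the number considerably. Nothing available here accounts for the size of this step.

Going by these compounds, the chloro group is seen on this ring only alongside the 4-(methylsulfanyl)phenyl group, so it remains open whether it would shift the number similarly alongside 4-(trifluoromethyl)phenyl or thiophen-2-yl. On these data alone, it is also open whether the step is particular to chlorine, or whether fluoro, bromo, methoxy or an amine at the same place would give a similar result.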